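Antiproliferative series: replacing 2,3-dimethylphenyl with 4-chlorophenyl

The compounds below may be only part of what the source reports. "The series", "measured", "known", "first", "only" and "open" are said of these compounds alone.

compound 1 `COc1cc(-n2cnc3ccc(-c4ccc(C(F)(F)F)cc4)cc32)cc(OC)c1OC`: 760 nM
compound 2 `COc1cc(-n2cnc3ccc(-c4cccc(C)c4)cc32)cc(OC)c1OC`: 360 nM
compound 3 `COc1cc(-n2cnc3ccc(-c4cccc(C)c4C)cc32)cc(OC)c1OC`: 2150 nM

All three values come from a functional assay on MCF7 cells (Homo sapiens) for antiproliferative activity, read by MTT assay, with a stated time of 72 h; a lower number here means a stronger inhibitor, a higher number a weaker inhibitor. Compound 3 stands highest at 2150 nM and is the weakest of the three, with its steps to both others beyond the scatter. Compound 4 `COc1cc(-n2cnc3ccc(-c4ccc(Cl)cc4)cc32)cc(OC)c1OC` has not yet been measured. Its difference from compound 3 is 4-chlorophenyl in place of 2,3-dimethylphenyl on an aromatic carbon, with 4-chlorophenyl in place of 2,3-dimethylphenyl on an aromatic carbon.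

All three measured steps bear on this change. Methyl in place of hydrogen gives a 6.0-fold higher number from compound 2 to compound 3 (0.78 log units; beyond the scatter), the largest step in the set. The closest group to 4-chlorophenyl is the 4-(trifluoromethyl)phenyl of compound 1, and the swap to 2,3-dimethylphenyl gives a 2.8-fold higher number from compound 1 to compound 3 (0.45 log units; beyond the scatter). The step between the other two aryl groups is smaller, at a 2.1-fold lower number from compound 1 to compound 2 (0.32 log units; beyond the scatter). Among the measured compounds shown here, no chlorinated compound has been measured, so the comparison with compound 1 remains indirect and the range is kept wide.

Leaving 2,3-dimethylphenyl should therefore lower the number in this assay by a modest step. The expected step is a 3.1-fold lower number from compound 3 to compound 4 (0.49 log units; beyond the scatter). For compound 4 the estimated value is 700 nM, with an expected range of 280 nM to 1700 nM.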

Compound 4, half-maximal inhibitory concentration: 1320 nM
Compound 4: middle estimate off by 1.9-fold (0.28 log units), on the low side, and the stated range covers the measured number.
By their numbers in this assay, from the lowest: compound 2; then compounds 1, 4 and 3 (each within the scatter of the next, the first and the last beyond it).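

In this assay, 4-chlorophenyl in place of 2,3-dimethylphenyl gives a 1.6-fold lower number from compound 3 to compound 4 (0.21 log units; within the scatter), so this change does not separate the two compounds, and chloro in place of trifluoromethyl gives a 1.7-fold higher number from compound 1 to compound 4 (0.24 log units; within the scatter), so these two groups on the phenyl ring are not told apart at this position either. Among the compounds shown here, the one clear step among the new ones is 4-chlorophenyl in place of 3-methylphenyl, with a 3.7-fold higher number from compound 2 to compound 4 (0.56 log units; beyond the scatter), which makes compound 2 the strongest of the four, its steps to all three others being beyond the scatter. Nothing on hand explains why these aryl groups give these numbers.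

Open, from the compounds shown here alone, is how the number responds to a methoxy group, an amine or a carboxylic acid on this phenyl ring. Also open, going by these compounds, is whether the gap between compound 2 and compound 4 follows from the change of methyl to chloro or from where the group sits on the phenyl ring, since these two compounds differ in both.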